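From Benzyl to Allyl on a Weakly Cytotoxic Core

The compounds below may be only part of what the source reports. "The series", "measured", "known", "first", "only" and "open" are said of these compounds alone.

Compound 3 `Cc1ccc(Cn2cc(C(N)=O)c3c(N)ncnc32)cc1` was tested in a functional assay on KB cells (Homo sapiens) for cytotoxicity; a higher number here means a weaker inhibitor, a lower number a stronger inhibitor. There compound 3 reaches only the limit of > 100000 nM, so no number stands for it. Its two neighbours do give numbers: compound 1 `Cc1ccc(Cn2cc(C(=N)S)c3c(N)ncnc32)cc1` gives 65000 nM in this assay, and compound 2 `COc1ccc(Cn2cc(C(N)=O)c3c(N)ncnc32)cc1` gives 47000 nM. The steps onto compound 3 are an at least 1.5-fold higher number from compound 1 to compound 3 (0.18 log units; that floor lies within the scatter) and an at least 2.1-fold higher number from compound 2 to compound 3 (0.32 log units; beyond the scatter); the set also includes (the limit of > 100000 nM in this assay, at which 1 of the 3 values shown sits). Compound 4 `C=CCn1cc(C(N)=O)c2c(N)ncnc21` differs from compound 3 by vinyl in place of 4-methylphenyl on a saturated chain carbon bound to an aromatic nitrogen. Neither measured step touches the group on the saturated chain carbon bound to the aromatic nitrogen, so nothing shown speaks to this change, and a step that the limit leaves unreadable from compound 3 to compound 4 is expected, with the value staying near the limit. Compound 4 is therefore estimated at 150000 nM, within 40000 nM to 600000 nM.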

Compound 4, half-maximal inhibitory concentration: 100000 nM
Compound 4: the middle estimate sits 1.5-fold (0.18 log units) above what was measured, within the range that was stated.
By their numbers in this assay, from the lowest: compounds 2, 1 and 4 (each within the scatter of the next, the first and the last beyond it).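

This is the only change shown at the group on the saturated chain carbon bound to the aromatic nitrogen, and in this assay compound 4, carrying vinyl, gives 100000 nM. The result is a number no higher from compound 3 to compound 4 (the limit leaves the size open). Losing the six-membered aromatic ring here therefore brings no higher number, though the size of the change stays unreadable: the limit of > 100000 nM in this assay, at which 1 of the 4 values shown sits.

The compounds shown leave open how a longer chain or an amine on this saturated chain carbon would read. They also leave open whether a carboxylic acid in place of the shared amide would lower the number.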